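From compound 3 to compound 4: methyl to fluoro

A few compounds are considered here, and "the series" means these few. Any claim that something is new, unique, unknown or untested is made for them only; others in the source may bear on it.

In an ADME assay on L6 cells (Rattus norvegicus) for cytotoxicity, read by fluorescence and resazurin assay, with a stated time of 72 h (on this read-out lower numbers stand for higher toxicity in this test and higher numbers for lower toxicity in this test), three compounds have been measured so far. Compound 1 (`Clc1ccc(-c2c[nH]cc2C(c2ccc(Cl)cc2)n2ccnc2)cc1`) gives 4830 nM, and compound 2 (`CSc1ccc(-c2c[nH]cc2C(c2ccc(Cl)cc2Cl)n2ccnc2)cc1`) gives 7220 nM. Compound 3 (`Cc1ccc(C(c2ccn(-c3ccc(Cl)cc3)c2)n2ccnc2)cc1`) gives 42600 nM, the highest of the three numbers, and its gaps to compound 1 and compound 2 both lie beyond the scatter.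

The next compound is compound 4 (`Fc1ccc(C(c2ccn(-c3ccc(Cl)cc3)c2)n2ccnc2)cc1`), which carries fluoro in place of methyl on an aromatic carbon, para to a large group: fluoro in place of methyl on an aromatic carbon. The same difference reads 4-methylphenyl to 4-fluorophenyl.

For the measured compounds named here, no two measured compounds differ in one place only, so the series offers no direct measure of this exchange. The working expectation in this assay is therefore no change beyond the scatter, in either direction, with compound 3 at 42600 nM as the anchor. The expected size is a 1.1-fold lower number from compound 3 to compound 4 (0.03 log units; within the scatter). For compound 4 the estimate is 40000 nM, with an expected range of 15000 nM to 90000 nM.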

Compound 4, half-maximal cytotoxic concentration: 63100 nM
Compound 4: the middle estimate sits 1.6-fold (0.20 log units) below what was measured; measured number inside the range.
By their numbers in this assay, from the lowest: compounds 1 and 2 (each within the scatter of the next); then compounds 3 and 4 (each within the scatter of the next).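

In this assay, fluoro in place of methyl on an aromatic carbon, para to a large group, gives a 1.5-fold higher number from compound 3 to compound 4 (0.17 log units; within the scatter). For the compounds shown here, this is the first exchange that can be read at a single place, and it shows that this position carries either group with no difference beyond the scatter. No evidence at hand bears on what lies behind this reading.

Open, from the compounds shown here alone, is whether an amine, a carboxylic acid or a longer chain at this position would stay within the scatter of compound 3 and compound 4. Also open, going by these compounds, is whether fluoro in place of methyl would read the same way on the core of compound 1, since this single exchange speaks only for the core of compound 3.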